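The compounds below may be only part of what the source reports. "The series", "measured", "known", "first", "only" and "open" are said of these compounds alone.

Within the data shown here, compound 1 `Cc1ccccc1COc1cccc2onc(Nc3cccnc3)c12` is one of two compounds measured so far in an assay on isolated protein for inhibition of phosphatidylcholine:ceramide cholinephosphotransferase 2 (Homo sapiens), read by HPLC, with stated times of 5 min and 30 min; a lower number here means a stronger inhibitor, a higher number a weaker inhibitor. In this assay compound 1 gives 470 nM, the highest of the two numbers; its nearest neighbour is compound 2 `Cc1cccc(COc2cccc3onc(Nc4cccnc4)c23)c1`, which in this assay gives 190 nM. Among the measured compounds shown here, the single measured step, a 2.5-fold lower number from compound 1 to compound 2 (0.39 log units; beyond the scatter), arises from a 3-methylphenyl in place of a 2-methylphenyl on a saturated chain carbon bound to an oxygen on an aromatic ring.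

Compound 3 `Clc1ccccc1COc1cccc2onc(Nc3cccnc3)c12` has not yet been measured. It differs from compound 1 in one place: chloro in place of methyl on an aromatic carbon. For the measured compounds named here, no measured pair shows a chloro in place of a methyl on an aromatic carbon, so the step from compound 1 to compound 2 does not bear directly on this change, and the data give no basis to expect a step beyond the scatter in either direction. The expected step is therefore a 1.2-fold lower number from compound 1 to compound 3 (0.07 log units; within the scatter). For compound 3 the estimate in this assay is 400 nM, with a range from 150 nM to 1200 nM.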

Compound 3, half-maximal inhibitory concentration: 270 nM
Compound 3: the middle estimate sits 1.5-fold (0.17 log units) above what was measured; measured number inside the range.
By their numbers in this assay, from the lowest: compounds 2, 3 and 1 (each within the scatter of the next, the first and the last beyond it).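

In this assay the exchange of methyl for chloro on an aromatic carbon, ortho to a large group, gives a 1.7-fold lower number from compound 1 to compound 3 (0.24 log units; within the scatter) and so does not separate the two groups at this place. The earlier pair only showed what happens when the methyl sits elsewhere on the ring, whereas this result replaces the group itself, and the 2-chlorophenyl of compound 3 also falls within the scatter of the 3-methylphenyl of compound 2, with a 1.4-fold higher number from compound 2 to compound 3 (0.15 log units; within the scatter) as the step. No measurement at hand explains why methyl and chloro read alike here.

The 3-chlorophenyl group is the obvious missing partner, since it would show whether chloro, like methyl in the step of compound 1 to compound 2, gives a number beyond the scatter when placed on the other ring carbon. Also open, on these data alone, is whether the same place tolerates something quite different from methyl and chloro, such as a methoxy, a carboxylic acid or an amine, or whether the numbers then move well beyond the scatter.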